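The source may hold more compounds than are shown below. What is called first, only, known or untested is meant among the compounds shown, and "the series" means these compounds.

Measured so far:
compound 1 `Cc1cc(C)c2nc(NCCCN)n(Cc3nc(C)ccc3O)c2c1` — 68 h
compound 2 `Cc1cc(C)c2nc(NCC(O)CO)n(Cc3nc(C)ccc3O)c2c1` — < 24 h

In an ADME assay on lung (Rattus norvegicus, strain Sprague-Dawley) for pharmacokinetics, with a stated time of 96 h (on this read-out lower numbers stand for a shorter-lived compound and higher numbers for a longer-lived compound), compound 1 gives 68 h. For compound 2 only a limit of the assay is known, < 24 h, and not a number. Compound 2 therefore stands at the limit of < 24 h in this assay, at which 1 of the 2 values shown sits, the short-lived end of the two values. Going by the values given here, the single measured step, an at least 2.8-fold lower number from compound 1 to compound 2 (0.45 log units; beyond the scatter), is the whole of what the series shows.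

Compound 3 `Cc1cc(C)c2nc(NCCCN3CCN(C)CC3)n(Cc3nc(C)ccc3O)c2c1` is not yet measured. It differs from compound 2 in one place: 2-(4-methylpiperazin-1-yl)ethyl in place of 1,2-dihydroxyethyl on a saturated chain carbon bound to a nitrogen on an aromatic ring. Among the compounds with values here, the only step that bears on this change is an at least 2.8-fold lower number from compound 1 to compound 2 (0.45 log units; beyond the scatter), and the change now made runs the other way, away from the dihydroxy chain. Compound 1, which carries 2-aminoethyl at the same place, gives 68 h. A rise in this assay of about an at least 2.0-fold higher number from compound 2 to compound 3 (0.31 log units; beyond the scatter) is therefore expected. Compound 3 is estimated at 50 h, with a range from 15 h to 150 h.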

Compound 3, half-life: 80 h
Estimate against measurement, compound 3: 1.6-fold (0.20 log units) below; low and high end bracket the measured number.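

In this assay the change from 2,3-dihydroxypropyl to 3-(4-methylpiperazin-1-yl)propyl gives an at least 3.3-fold higher number from compound 2 to compound 3 (0.52 log units; beyond the scatter). Replacing amino with 4-methylpiperazin-1-yl gives a 1.2-fold higher number from compound 1 to compound 3 (0.07 log units; within the scatter), so the chain end at this place can carry a six-membered non-aromatic ring with 2 hetero atoms without a change beyond the scatter. Compound 2 is known only as a limit, so the step from it gives a bound and not a size: the limit of < 24 h in this assay, at which 1 of the 3 values shown sits.

Two chains ending in nitrogen groups against one dihydroxy chain are too few to establish a pattern, and the compounds shown do not separate the role of the chain end from that of the hydroxyl groups. On these data alone, a morpholine or a carboxylic acid at the chain end, or a longer chain carrying the same 4-methylpiperazin-1-yl group, remains open.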